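A one-carbon extension of the hydroxyalkynyl chain

A few compounds are considered here, and "the series" means these few. Any claim that something is new, unique, unknown or untested is made for them only; others in the source may bear on it.

Measured in an ADME assay on HepG2 cells (Homo sapiens) for cytotoxicity, read by MTT assay, with a stated time of 72 h; on this read-out higher numbers stand for lower toxicity in this test and lower numbers for higher toxicity in this test:
- Compound 1 `O=[N+]([O-])c1c(CS(=O)(=O)c2ccccc2)nc2c(C#Cc3ccc(F)cc3)cc(Cl)cn12`: > 3900 nM, a limit of the assay and not a number.
- Compound 2 `O=[N+]([O-])c1c(CS(=O)(=O)c2ccccc2)nc2c(C#Cc3cccnc3)cc(Cl)cn12`: > 3900 nM, also a limit of the assay and not a number.
- Compound 3 `O=[N+]([O-])c1c(CS(=O)(=O)c2ccccc2)nc2c(C#CCO)cc(Cl)cn12`: 10100 nM.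

Compound 3 is the only one of the three with a measured number, 10100 nM, so its place relative to the other two cannot be ranked. The two others sit at the limit of > 3900 nM in this assay, at which 2 of the 3 values shown sit.

Compound 4 `O=[N+]([O-])c1c(CS(=O)(=O)c2ccccc2)nc2c(C#CCCO)cc(Cl)cn12` differs from compound 3 in one place: hydroxymethyl in place of hydroxy on a saturated chain carbon bound to a triple-bonded carbon. This is hydroxymethyl in place of hydroxy on a saturated chain carbon bound to a triple-bonded carbon, which turns 3-hydroxyprop-1-yn-1-yl into 4-hydroxybut-1-yn-1-yl.

The nearest measured changes are at the same alkyne substituent, and they give no size: a step that the limit leaves unreadable from compound 1 to compound 3, and a step that the limit leaves unreadable from compound 2 to compound 3. Among the measured compounds shown here, neither of them extends a hydroxyalkyl chain, and none of the measured compounds tests that change directly. The expectation therefore rests on compound 3 at 10100 nM and on the small size of the structural change.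

Expected in this assay is a 1.0-fold lower number from compound 3 to compound 4 (0.00 log units; within the scatter), which means no step beyond the scatter and no favoured direction. In this assay the estimate for compound 4 is 10000 nM, expected to fall between 4000 nM and 25000 nM.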

Compound 4, half-maximal cytotoxic concentration: > 125000 nM
Compound 4: only a limit was reported (the forecaster's own chance of this, stated with the estimate: 30%); middle value at least 12-fold (1.09 log units) from the limit.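

In this assay the extension to 4-hydroxybut-1-yn-1-yl gives an at least 12-fold higher number from compound 3 to compound 4 (1.09 log units; beyond the scatter). Among the compounds shown here, this is the first readable step, and it shows that a change as small as hydroxymethyl in place of hydroxy on a saturated chain carbon bound to a triple-bonded carbon can move this read-out beyond the scatter, towards lower toxicity in this test. The value of compound 4, > 125000 nM, is a limit of the assay and not a number: the limit of > 125000 nM in this assay, at which 1 of the 4 values shown sits.

From the compounds shown here alone, the steps from compound 1 and from compound 2 to compound 4 cannot be read, so how 2-hydroxyethyl compares with 4-fluorophenyl or pyridin-3-yl on the triple-bonded carbon stays unknown. The compounds shown also leave open whether the trend continues with a longer hydroxyalkyl chain, and whether the hydroxy group matters to it at all, which an amine or a carboxylic acid in its place, or a plain butynyl chain, would begin to test.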